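Replacing a Chloro Group with 1H-imidazol-4-yl

The compounds below may be only part of what the source reports. "The series", "measured", "known", "first", "only" and "open" are said of these compounds alone.

In a functional assay on cells (Erythrocyte, Rattus norvegicus) for inhibition, read by hemolysis, with a stated time of 1 h (a lower number here means a stronger inhibitor, a higher number a weaker inhibitor), compound 1 (`COc1cc(OC)c(OC)cc1/C=C/C(=O)c1ccc(Cl)cc1`) gives 2.3 ug/mL. Two relatives share the core of compound 1 but carry different groups on the other side of the carbonyl: compound 2 (`COc1cc(OC)c(OC)cc1/C=C/C(=O)c1cc(OC(C)=O)ccc1OC(C)=O`) gives 2.33 ug/mL, and compound 3 (`COc1cc(OC)c(OC)cc1/C=C/C(=O)c1cc(Cc2ccccc2)cc(Cc2ccccc2)c1`) gives 2.17 ug/mL. Compound 2 is the nearest neighbour of compound 1 and compound 3 the furthest, yet all three lie within the usual scatter of repeated measurements, so these numbers cannot rank them.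

The next compound to be tested is compound 4 (`COc1cc(OC)c(OC)cc1/C=C/C(=O)c1ccc(-c2c[nH]cn2)cc1`). It keeps the core of compound 1 and makes one change: 1H-imidazol-4-yl in place of chloro on an aromatic carbon. For the measured compounds named here, no two measured compounds differ in only one place, and none carries a 1H-imidazol-4-yl group, so there is no direct precedent for this swap. The best guide is how little this assay has moved so far, with compound 2 at 2.33 ug/mL and compound 3 at 2.17 ug/mL despite their quite different groups. A step beyond the scatter therefore seems unlikely, in either direction, and the expected step of no change at the digits printed from compound 1 to compound 4 (within the scatter) is small. For compound 4 the estimated value is 2.3 ug/mL, within a range of 1.2 ug/mL to 4.5 ug/mL.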

Compound 4, half-maximal inhibitory concentration: 2.48 ug/mL
For compound 4 the middle estimate is 1.1-fold (0.03 log units) below the measured one, and the stated range covers the measured number.
By their numbers in this assay, from the lowest: compounds 3, 1, 2 and 4 (each within the scatter of the next).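

In this assay, placing 1H-imidazol-4-yl in place of chloro on an aromatic carbon gives a 1.1-fold higher number from compound 1 to compound 4 (0.03 log units; within the scatter), and this is the only step shown between two compounds that differ in just one place. It therefore adds something that compounds 2 and 3 could not show: at this position, para to a large group, a single atom can be exchanged for a group of 5 heavy atoms, including a five-membered aromatic ring with 2 hetero atoms, 1 hydrogen-bond donor and 1 hydrogen-bond acceptor, with no step beyond the scatter. Nothing shown here explains why the number stays within the scatter, so this single swap supports no conclusion about how the position interacts with either group.

As far as these compounds go, it remains open whether a carboxylic acid, an amine or a longer chain such as hexyl at this same position would produce a step beyond the scatter. Also unresolved is whether this insensitivity extends to changes elsewhere on the shared core, since every other pair of compounds shown differs in more than one place.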